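A hydroxy group added to compound 3

A few compounds are considered here, and "the series" means these few. Any claim that something is new, unique, unknown or untested is made for them only; others in the source may bear on it.

In a functional assay on Gurav cells (Homo sapiens) for inhibition, read by sulforhodamine B assay (a lower number here means a stronger inhibitor of growth, a higher number a weaker inhibitor of growth), compound 3 (`Clc1cccc(-c2ccc(-c3ccc(-c4nc5ccccc5[nH]4)cc3)cc2)c1`) gives 2190 nM. That sits level with compound 1 (`Cc1ccc2[nH]c(-c3ccc(-c4ccc(-c5cccc(Cl)c5)cc4)cc3)nc2c1`) at 2120 nM and far below compound 2 (`CN(C)c1ccc(-c2ccc(-c3ccc(-c4nc5ccccc5[nH]4)cc3)cc2)cc1`) at 100000 nM. Compound 4 (`Oc1cccc2[nH]c(-c3ccc(-c4ccc(-c5cccc(Cl)c5)cc4)cc3)nc12`) differs from compound 3 by hydroxy in place of hydrogen on an aromatic carbon. The closest guide is a 1.0-fold higher number from compound 1 to compound 3 (0.01 log units; within the scatter), also a small swap on an aromatic carbon, and it stays within the scatter. The large 46-fold lower number from compound 2 to compound 3 (1.66 log units; beyond the scatter) exchanges a whole 4-(dimethylamino)phenyl group and says little here. Within the data shown here, no measured compound carries a hydroxy group, so the uncertainty is wide. The expected step is a 1.1-fold higher number from compound 3 to compound 4 (0.06 log units; within the scatter), with no change beyond the scatter anticipated. Compound 4 is expected at 2500 nM, an estimate ranging from 800 nM to 9000 nM.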

Compound 4, concentration for 50% growth inhibition: 2310 nM
Beside the measured number, compound 4's estimate is 1.1-fold (0.03 log units) above it, within the range that was stated.
By their numbers in this assay, from the lowest: compounds 1, 3 and 4 (each within the scatter of the next); then compound 2.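

In this assay hydroxy in place of hydrogen on this six-membered aromatic ring of carbon only gives a 1.1-fold higher number from compound 3 to compound 4 (0.02 log units; within the scatter) and leaves the number within the scatter. This position therefore accepts a group with a hydrogen-bond donor and acceptor, where the earlier compounds had shown only a methyl swap on this ring. Nothing available gives a reason for this flat result. From the compounds shown here alone, whether an amine or a carboxylic acid here would also leave growth inhibition unchanged stays open.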